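Ethoxy for hydrogen on the anilide ring of compound 2

This account rests on a few compounds, and the source may have more. Where it says the series, first, only, none or still open, it means among the compounds named here.

Three ureas built on the same core have been tested in a functional assay on the whole organism (strain albino) with Mus musculus as the target, at a dose of 100 mg/kg by the intraperitoneal route; a lower number here means less inhibition, a higher number more inhibition at the dose given (going by the name of the read-out). Compound 1 `O=C(Nc1ccc(I)cc1)Nn1c(-c2ccccc2)nc2ccccc2c1=O` gives 60%, compound 2 `O=C(Nc1ccccc1)Nn1c(-c2ccccc2)nc2ccccc2c1=O` gives 56%, and compound 3 `CCc1ccc(NC(=O)Nn2c(-c3ccccc3)nc3ccccc3c2=O)cc1` gives 61%. Compound 2 carries the smallest of these three numbers, yet both gaps to it, a number 4 percentage points lower from compound 1 to compound 2 (within the scatter) and a number 5 percentage points higher from compound 2 to compound 3 (within the scatter), stay within the scatter, so the three compounds cannot be separated on this read-out; the third step, a number 1 percentage points higher from compound 1 to compound 3 (within the scatter), is likewise within the scatter.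

The next compound, compound 4 `CCOc1ccc(NC(=O)Nn2c(-c3ccccc3)nc3ccccc3c2=O)cc1`, differs from compound 2 in one place: ethoxy in place of hydrogen on an aromatic carbon. The change sits on the same aromatic carbon where compound 3 carries its ethyl, para to a large group. The step that bears most directly on this is a number 5 percentage points higher from compound 2 to compound 3 (within the scatter), which put a three-atom-free ethyl chain at that carbon without moving the read-out beyond the scatter; the steps involving iodo at the same carbon were equally flat. An ethoxy group there is therefore expected to give a step of about a number 2 percentage points higher from compound 2 to compound 4 (within the scatter) in this assay, that is, none beyond the scatter in either direction. Compound 4 is estimated to reach 58%, with a range from 45% to 70%.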

Compound 4, a percentage reported as inhibition, in the whole organism at one dose (the size of the read-out at that dose, not a potency): 53%
Compound 4: the middle estimate sits 5 percentage points above what was measured, within the range that was stated.
By their numbers in this assay, from the lowest: compounds 4, 2, 1 and 3 (each within the scatter of the next).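

With ethoxy on this aromatic carbon, the ring now carries a group holding oxygen, and the step in this assay still stays within the scatter (a number 3 percentage points lower from compound 2 to compound 4 (within the scatter)). The direct exchanges at the same carbon are new as well, since ethoxy in place of ethyl (a number 8 percentage points lower from compound 3 to compound 4 (within the scatter)) and ethoxy in place of iodo (a number 7 percentage points lower from compound 1 to compound 4 (within the scatter)) are both within the scatter, so hydrogen, iodo, ethyl and ethoxy cannot be separated here on this single-dose read-out, although ethoxy and ethyl are of similar size in heavy atoms and differ by that oxygen. No measurement at hand accounts for this flat picture, and none says whether these groups act alike at other doses.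

The compounds shown leave open whether a group of another kind on this carbon, such as an amine or a carboxylic acid, or a longer chain such as butoxy, would give a step beyond the scatter. They also leave open whether ethoxy on a different carbon of this ring would read the same, and, with one dose only, how these ureas compare in potency.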